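Furan-2-yl at the saturated ring carbon: compound 4 expected

The source may hold more compounds than are shown below. What is called first, only, known or untested is meant among the compounds shown, and "the series" means these compounds.

Of the compounds shown here, three sharing one core have been measured in an assay on isolated protein for inhibition of Amine oxidase [flavin-containing] A (Homo sapiens), read by fluorescence; on this read-out lower numbers stand for stronger inhibition and higher numbers for weaker inhibition. Compound 1, `CC(=O)N1N=C(c2cc(O)c(O)c([N+](=O)[O-])c2)CC1c1cccs1`, gives 86300 nM. Compound 2, `CC(=O)N1N=C(c2cc(O)c(O)c([N+](=O)[O-])c2)CC1c1ccoc1`, gives 90900 nM. Compound 3, `CC(=O)N1N=C(c2cc(O)c(O)c([N+](=O)[O-])c2)CC1c1cccc(C#N)c1`, gives 70600 nM, which is the lowest of the three numbers, though every step between them stays within the scatter: a 1.1-fold higher number from compound 1 to compound 2 (0.02 log units; within the scatter), a 1.2-fold lower number from compound 1 to compound 3 (0.09 log units; within the scatter) and a 1.3-fold lower number from compound 2 to compound 3 (0.11 log units; within the scatter).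

The compound now in question is compound 4, `CC(=O)N1N=C(c2cc(O)c(O)c([N+](=O)[O-])c2)CC1c1ccco1`. The change from compound 3 is furan-2-yl in place of 3-cyanophenyl on a saturated ring carbon.

All three measured steps bear on this change, since each of them swaps one ring at the same saturated ring carbon, and none of them moved the number beyond the scatter. In particular the exchange between thiophen-2-yl and furan-3-yl in the step from compound 1 to compound 2, and the exchange of either of these for 3-cyanophenyl, left the half-maximal inhibitory concentration essentially where it was. No step beyond the scatter is therefore expected in this assay for furan-2-yl either.

Compound 4 is accordingly estimated at 85000 nM, within the range 42000 nM to 170000 nM, which means an expected step of a 1.2-fold higher number from compound 3 to compound 4 (0.08 log units; within the scatter).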

Compound 4, half-maximal inhibitory concentration: 98000 nM
Beside the measured number, compound 4's estimate is 1.2-fold (0.06 log units) below it; low and high end bracket the measured number.
By their numbers in this assay, from the lowest: compounds 3, 1, 2 and 4 (each within the scatter of the next).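

In this assay the furan-2-yl ring joins the other three rings on the saturated ring carbon without separating from them: there is a 1.4-fold higher number from compound 3 to compound 4 (0.14 log units; within the scatter) and a 1.1-fold higher number from compound 2 to compound 4 (0.03 log units; within the scatter) and also a 1.1-fold higher number from compound 1 to compound 4 (0.06 log units; within the scatter) in the comparison with the thiophen-2-yl compound. Among these compounds, the exchange of furan-3-yl for furan-2-yl adds a new kind of change at this position, since the same ring is now attached differently, and the exchange of 3-cyanophenyl for furan-2-yl spans a larger difference in heavy atoms than the earlier steps between the two five-membered rings, yet neither step leaves the scatter. Nothing available explains why the number stays so flat across these four rings.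

The compounds shown leave open whether any group on this carbon would move the number beyond the scatter, for instance a phenyl ring carrying an amine or a carboxylic acid, or a longer alkyl chain in place of an aromatic ring. They also leave open what happens when the acetyl group gives way to a longer acyl chain, since it stays the same in all four compounds.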